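This account rests on a few compounds, and the source may have more. Where it says the series, first, only, none or still open, it means among the compounds named here.

Among the measured compounds shown here, compound 1, `CN1CCN(C[C@H]2CN(c3ccc(-n4cc(-c5ccccn5)cn4)c(F)c3)C(=O)O2)CC1`, is one of three compounds measured in a physicochemical assay for lipophilicity, read by HPLC, measured as octanol-water partition (a higher number here means a more lipophilic compound, a lower number a more polar compound), and compound 1 gives 2.2. Compound 2, `O=C1O[C@@H](CN2CCC(O)CC2)CN1c1ccc(-n2cc(-c3ccccn3)cn2)c(F)c1`, gives 1.63, while compound 3, `O=C(OC[C@H]1CN(c2ccc(-n3cc(-c4ccccn4)cn3)c(F)c2)C(=O)O1)c1ccccc1`, gives 4.21. Compound 1 therefore holds the second highest of the three numbers: the step of a number 0.57 log units lower from compound 1 to compound 2 (beyond the scatter) is modest, the step of a number 2.01 log units higher from compound 1 to compound 3 (beyond the scatter) is large, and the step of a number 2.58 log units higher from compound 2 to compound 3 (beyond the scatter) is the largest among them.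

Compound 4, `NC(=O)[C@H]1CN(c2ccc(-n3cc(-c4ccccn4)cn3)c(F)c2)C(=O)O1`, is not yet measured. It differs from compound 1 in one place: carbamoyl in place of (4-methylpiperazin-1-yl)methyl on a saturated ring carbon. The two steps that bear on this change are those leaving compound 1 at the same side of the shared core. Exchanging the 4-methylpiperazin-1-yl group for a 4-hydroxypiperidin-1-yl group lowered the number modestly, whereas exchanging it for a benzoyloxy group raised it by a large step. For the measured compounds named here, the change to carbamoyl has no measured counterpart, so the expectation rests on the direction of the step to compound 2. For compound 4 a modest step downward is expected, a number 0.40 log units lower from compound 1 to compound 4 (beyond the scatter). The value estimated for compound 4 in this assay is 1.8, with a range from 1.2 to 2.4.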

Compound 4, partition coefficient: 1.59
For compound 4 the middle estimate is 0.21 log units above the measured one, and the stated range covers the measured number.
By their numbers in this assay, from the lowest: compounds 4 and 2 (each within the scatter of the next); then compound 1; then compound 3.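

In this assay, putting carbamoyl in place of (4-methylpiperazin-1-yl)methyl on a saturated ring carbon, next to the ring oxygen, gives a number 0.61 log units lower from compound 1 to compound 4 (beyond the scatter), so this position takes a group with no ring and without the chain carbon that compounds 1, 2 and 3 carry there. With a number 0.04 log units lower from compound 2 to compound 4 (within the scatter), carbamoyl and (4-hydroxypiperidin-1-yl)methyl cannot be told apart at this position, while a number 2.62 log units lower from compound 3 to compound 4 (beyond the scatter) leaves (benzoyloxy)methyl far from carbamoyl. Nothing available explains these steps.

The compounds shown leave open how a carboxylic acid or a methyl ester on this ring carbon would compare with carbamoyl in this assay. They also leave open what a carbamoylmethyl group would show, since it would keep the chain carbon while carrying the same carbamoyl, and so would separate the effect of that carbon from the effect of the group at its end.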